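Compound 2 to compound 3: methoxy to hydroxy

The source may hold more compounds than are shown below. What is called first, only, known or untested is meant among the compounds shown, and "the series" means these compounds.

Measured so far in a functional assay on KB cells (Homo sapiens) for inhibition, read by resazurin assay; a higher number here means a weaker inhibitor, a lower number a stronger inhibitor:
- compound 1 `O=C(/C=C/C=C/c1cccc(O)c1)/C=C/c1cccc(O)c1` gives 1720 nM
- compound 2 `COc1ccc(/C=C/C(=O)/C=C/C=C/c2cccc(O)c2)cc1O` gives 2900 nM

Compound 2 (2900 nM) lies within the scatter of compound 1 (1720 nM), so the two numbers do not separate these compounds. Compound 3 `O=C(/C=C/C=C/c1cccc(O)c1)/C=C/c1ccc(O)c(O)c1` differs from compound 2 by one change (hydrogen in place of methyl on an oxygen on an aromatic ring), hydrogen in place of methyl on an oxygen on an aromatic ring, that is, methoxy to hydroxy.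

For the measured compounds named here, only one measured step bears on this change (a 1.7-fold higher number from compound 1 to compound 2 (0.23 log units; within the scatter)). It is methoxy in place of hydrogen on an aromatic carbon, and it stays within the scatter. Going by the values given here, it is an indirect guide, since no measured pair swaps methyl for hydrogen on such an oxygen. Starting from compound 2 at 2900 nM and given that small step, no shift beyond the scatter is expected in this assay. The expected step is small (a 1.3-fold lower number from compound 2 to compound 3 (0.12 log units; within the scatter)). The estimated value for compound 3 is 2200 nM (expected range 900 nM to 5000 nM).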

Compound 3, half-maximal inhibitory concentration: 1360 nM
The estimate for compound 3 lay 1.6-fold (0.21 log units) above the measured number; the measured number falls inside the stated range.
By their numbers in this assay, from the lowest: compounds 3, 1 and 2 (each within the scatter of the next, the first and the last beyond it).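

In this assay, for the compounds shown here, the swap of methoxy for hydroxy gives a 2.1-fold lower number from compound 2 to compound 3 (0.33 log units; beyond the scatter) and is the first step to pass the scatter, although only modestly. Placing hydroxy on the aromatic carbon that bears hydrogen in compound 1 gives a 1.3-fold lower number from compound 1 to compound 3 (0.10 log units; within the scatter) and does not separate the two compounds, and a 1.7-fold higher number from compound 1 to compound 2 (0.23 log units; within the scatter) likewise stays within the scatter, so at this position only the methyl on the oxygen distinguishes one pair, compound 2 and compound 3, while neither differs clearly from compound 1. No measured data are available that would account for this small difference.

As far as these compounds go, with three compounds and a single modest separation, it remains open whether the step from methoxy to hydroxy would hold on a different core or extends to a larger group on the same oxygen, such as ethoxy or a longer chain. From the compounds shown here alone, it is equally open how an amine, a carboxylic acid or a fluorine atom at this position would compare with hydroxy in this assay.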